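Extending the Alkyne Chain: From Compound 1 to Compound 4

A few compounds are considered here, and "the series" means these few. Any claim that something is new, unique, unknown or untested is made for them only; others in the source may bear on it.

Compound 1 `CCCCCCC#Cc1cc2cn(COCCO)c(=O)nc2o1` was examined in a functional assay on HEL cells (Homo sapiens), read by microscopy; a higher number here means that more compound is tolerated, a lower number that less compound is tolerated. In this assay compound 1 gives > 200000 nM, which is a limit of the assay rather than a number. Among the three compounds measured, compound 1 sits at the limit of > 200000 nM in this assay, at which 1 of the 3 values shown sits. The two companions give numbers: compound 2 `CCCCCCCc1cc2cn(COCCO)c(=O)nc2o1` gives 400000 nM, and compound 3 `CCCCCCCCc1cc2cn(COCCO)c(O)nc-2n1`, whose core differs, gives 80000 nM. Compound 4 `CCCCCCCCCC#Cc1cc2cn(COCCO)c(=O)nc2o1` remains to be measured. It differs from compound 1 by propyl in place of hydrogen on a saturated chain carbon, six bonds along the chain from a triple-bonded carbon. Among the compounds with values here, no step between measured compounds is available to anchor the size of this change. The change is expected to lower the tolerated concentration somewhat, an expected step of an at least 2.0-fold lower number from compound 1 to compound 4 (0.30 log units; that floor lies within the scatter). Compound 4 is estimated at 100000 nM, within a range from 30000 nM to 400000 nM.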

Compound 4, minimum cytotoxic concentration: >= 20000 nM
Compound 4 gave a limit, no number; the forecaster's own chance of this, stated with the estimate: 30%; the middle value lies beyond the limit too.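

Compound 1 and compound 4 each give only a limit in this assay, and no step can be read between them. The compounds shown leave open how far propyl in place of hydrogen shifts the tolerated concentration.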